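The source may hold more compounds than are shown below. What is called first, only, known or untested is meant among the compounds shown, and "the series" means these compounds.

Working notes on the series. Compound 1 `Fc1ccc(C(SCCNC2CCN(Cc3ccccc3)CC2)c2ccc(F)cc2)cc1` gives 32.9 nM in an assay on membranes from striatum (strain Sprague-Dawley) for displacement of a labelled ligand from sodium-dependent dopamine transporter (Rattus norvegicus), read by scintillation counting, with a stated time of 120 min; a higher number here means a weaker inhibitor, a lower number a stronger inhibitor. Compound 2 `O=C(c1ccc(F)cc1)N1CCC(NCCSC(c2ccc(F)cc2)c2ccc(F)cc2)CC1` gives 7.04 nM in the same assay. Compound 3 `Fc1ccc(C(SCCNC2CCN(Cc3cc4ccccc4[nH]3)CC2)c2ccc(F)cc2)cc1` gives 179 nM, the highest number of the three. Its nearest neighbour is compound 1, the gap being a 5.4-fold higher number from compound 1 to compound 3 (0.74 log units; beyond the scatter); the furthest is compound 2, with a 25-fold higher number from compound 2 to compound 3 (1.41 log units; beyond the scatter).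

The next step replaces the group on the ring nitrogen of compound 3: (tert-butyl)carbonyl in place of (1H-indol-2-yl)methyl on an amine nitrogen in a ring, giving compound 4 `CC(C)(C)C(=O)N1CCC(NCCSC(c2ccc(F)cc2)c2ccc(F)cc2)CC1`. Among the measured compounds shown here, two measured steps bear on it. The step of a 25-fold higher number from compound 2 to compound 3 (1.41 log units; beyond the scatter) is the reverse kind of change, an (1H-indol-2-yl)methyl replacing a carbonyl-linked group on that nitrogen, and the step of a 4.7-fold lower number from compound 1 to compound 2 (0.67 log units; beyond the scatter) shows a carbonyl-linked group giving a lower number than a benzyl. Both point the same way, so a carbonyl-linked group in place of (1H-indol-2-yl)methyl is expected to give a markedly lower number in this assay; that the entering group is (tert-butyl)carbonyl rather than (4-fluorophenyl)carbonyl leaves the size uncertain, and the step is expected to be a 12-fold lower number from compound 3 to compound 4 (1.08 log units; beyond the scatter). Compound 4 is therefore estimated at 15 nM, within a range of 4 nM to 60 nM.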

Compound 4, inhibition constant: 352 nM
Compound 4: the middle estimate sits 23-fold (1.37 log units) below what was measured, and the stated range ends below it.
By their numbers in this assay, from the lowest: compound 2; then compound 1; then compounds 3 and 4 (each within the scatter of the next).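

This position does not reward the carbonyl link as such: with (tert-butyl)carbonyl on the amine nitrogen in a ring, the step is a 2.0-fold higher number from compound 3 to compound 4 (0.29 log units; within the scatter) and leaves compound 4 level with the (1H-indol-2-yl)methyl compound. Among the compounds shown here, what the carbonyl carries decides the outcome, and tert-butyl in place of 4-fluorophenyl on the carbonyl carbon gives a 50-fold higher number from compound 2 to compound 4 (1.70 log units; beyond the scatter) as the largest step so far. The earlier reading that a carbonyl-linked group beats benzyl holds for compound 2 only, and compound 4 goes against it with an 11-fold higher number from compound 1 to compound 4 (1.03 log units; beyond the scatter) for (tert-butyl)carbonyl in place of benzyl.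

No measurement among these compounds gives a reason for these steps.

The compounds shown leave open whether the aromatic ring on the carbonyl or the fluorine on that ring carries the low number of compound 2, a question that a plain benzoyl and a cyclohexylcarbonyl on the same nitrogen would separate. On these data alone, it also stays open whether a smaller acetyl group behaves like (tert-butyl)carbonyl here.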